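A fluorine added beside fluorine on the pyrazolone ring

The compounds below may be only part of what the source reports. "The series", "measured", "known", "first", "only" and "open" are said of these compounds alone.

Of the compounds shown here, three sharing one core have been measured in a functional assay on MCF7 cells (Homo sapiens) for cytotoxicity, read by MTT assay, with a stated time of 72 h (on this read-out lower numbers stand for stronger inhibition and higher numbers for weaker inhibition), and they differ only in the aryl group on the ring nitrogen. Compound 1 `Cc1cc(=O)n(-c2ccccc2OC(F)(F)F)nc1C(=O)Nc1ccc(Oc2ncnc3ccsc23)c(F)c1` gives 11500 nM, compound 2 `Cc1cc(=O)n(-c2cccc(F)c2)nc1C(=O)Nc1ccc(Oc2ncnc3ccsc23)c(F)c1` gives 9050 nM, and compound 3 `Cc1cc(=O)n(-c2ccc(F)cc2)nc1C(=O)Nc1ccc(Oc2ncnc3ccsc23)c(F)c1` gives 740 nM, the lowest of the three numbers. The steps tell how much the position of a substituent matters: a 1.3-fold lower number from compound 1 to compound 2 (0.10 log units; within the scatter), whereas a 16-fold lower number from compound 1 to compound 3 (1.19 log units; beyond the scatter) and a 12-fold lower number from compound 2 to compound 3 (1.09 log units; beyond the scatter). Compound 4 `Cc1cc(=O)n(-c2ccc(F)c(F)c2)nc1C(=O)Nc1ccc(Oc2ncnc3ccsc23)c(F)c1` is the next step from compound 3: fluoro in place of hydrogen on an aromatic carbon, placed ortho to the existing fluoro group and meta to the large group. Among the compounds with values here, no measured step adds a second fluorine, so no direct precedent exists; compound 2 shows that a fluorine at that position alone gives a high number, but compound 4 keeps the fluorine of compound 3 as well. The expected step is therefore small, a 1.6-fold higher number from compound 3 to compound 4 (0.21 log units; within the scatter), and compound 4 is estimated at 1200 nM, within 400 nM to 4000 nM.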

Compound 4, half-maximal inhibitory concentration: 6900 nM
Beside the measured number, compound 4's estimate is 5.8-fold (0.76 log units) below it, outside the stated range (above it).
By their numbers in this assay, from the lowest: compound 3; then compounds 4, 2 and 1 (each within the scatter of the next).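

In this assay, the fluoro group that enters ortho to the existing fluoro group cancels most of what sets compound 3 apart (a 9.3-fold higher number from compound 3 to compound 4 (0.97 log units; beyond the scatter)). Keeping the fluorine of compound 3 is therefore not enough: this one added atom, meta to the large group, is enough to lose that advantage. The 3,4-difluorophenyl compound cannot be told apart from the other two compounds (a 1.3-fold lower number from compound 2 to compound 4 (0.12 log units; within the scatter); a 1.7-fold lower number from compound 1 to compound 4 (0.22 log units; within the scatter)), so among these four aryl groups only 4-fluorophenyl stands out, with the lowest number.

Nothing measured here explains why a single fluorine has so large an effect.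

Still open, from the compounds shown here alone, is whether chlorine, a methyl group or a methoxy group at this position would give a number like that of compound 3 or like that of compound 4.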